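A few compounds are considered here, and "the series" means these few. Any claim that something is new, unique, unknown or untested is made for them only; others in the source may bear on it.

Compound 1 `COc1ccc(/C=N/NC(=O)c2ccc(C)cc2O)cc1` gives 723000 nM.
Compound 2 `Cc1ccc(C(=O)N/N=C/c2ccccc2F)c(O)c1` gives 362000 nM.

Both values come from an ADME assay on cells (Mus musculus, strain BALB/C) for cytotoxicity, read by MTT assay, with a stated time of 24 h; on this read-out lower numbers stand for higher toxicity in this test and higher numbers for lower toxicity in this test. Compound 2 stands lowest of the two numbers there, but its nearest neighbour, compound 1, lies within the scatter of it, so no order can be read between them. Compound 3 `Cc1ccc(C(=O)N/N=C/c2ccccc2)c(O)c1` differs from compound 2 by hydrogen in place of fluoro on an aromatic carbon. Among the measured compounds shown here, no step between measured compounds is available, and the two values shown do not separate. Compound 3 is therefore expected to show no step beyond the scatter, a 1.1-fold higher number from compound 2 to compound 3 (0.04 log units; within the scatter). Compound 3 is estimated at 400000 nM, between 150000 nM and 1000000 nM.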

Compound 3, half-maximal cytotoxic concentration: 578000 nM
Beside the measured number, compound 3's estimate is 1.4-fold (0.16 log units) below it; the measured number falls inside the stated range.
By their numbers in this assay, from the lowest: compounds 2, 3 and 1 (each within the scatter of the next).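

Hydrogen in place of fluoro on an aromatic carbon gives (a 1.6-fold higher number from compound 2 to compound 3 (0.20 log units; within the scatter)) in this assay, and dropping the methoxy group gives (a 1.3-fold lower number from compound 1 to compound 3 (0.10 log units; within the scatter)). With compound 3 as the hydrogen reference, neither single change separates from the scatter, so neither fluoro nor methoxy has a readable effect on this number. No measurement is available that would explain this result. The compounds shown leave open whether a larger change on this aromatic carbon, such as an amine or a carboxylic acid, would give a step beyond the scatter.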